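Removing the chloro from the urea aryl of compound 3

A few compounds are considered here, and "the series" means these few. Any claim that something is new, unique, unknown or untested is made for them only; others in the source may bear on it.

Compound 3 `COc1cc(Cl)cc(-c2nn(-c3cccc(NC(=O)Nc4ccc(Cl)c(C(F)(F)F)c4)c3)cc2-c2ccncc2)c1` gives 98% in a functional assay on SF-295 cells (Homo sapiens) for inhibition, read by sulforhodamine B assay, with a stated time of 48 h, tested at 0.1 uM (on this read-out lower numbers stand for a stronger effect and higher numbers for a weaker effect at the one concentration tested), the highest of the three numbers in hand. Its nearest neighbour is compound 1 `O=C(Nc1cccc(-n2cc(-c3ccncc3)c(-c3cc(O)cc(Cl)c3)n2)c1)Nc1ccc(Cl)c(C(F)(F)F)c1`, which gives 93% in this assay; the two lie within the scatter of each other. Compound 2 `O=C(Nc1cccc(-n2cc(-c3ccncc3)c(-c3cc(O)cc(Cl)c3)n2)c1)Nc1ccc(Cl)c(Cl)c1` gives 87% in this assay, and the gap between compound 2 and compound 3 lies beyond the scatter. Both measured steps are small: a number 6 percentage points lower from compound 1 to compound 2 (within the scatter) and a number 5 percentage points higher from compound 1 to compound 3 (within the scatter), each within the scatter. One swaps chloro for trifluoromethyl on an aromatic carbon, the other puts methyl in place of hydrogen on an oxygen on an aromatic ring.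

Compound 4 `COc1cc(Cl)cc(-c2nn(-c3cccc(NC(=O)Nc4cccc(C(F)(F)F)c4)c3)cc2-c2ccncc2)c1` differs from compound 3 in a single place: hydrogen in place of chloro on an aromatic carbon. Among the compounds with values here, no measured step removes a chloro from this ring, so nothing bears on the change directly; the only known steps, a number 6 percentage points lower from compound 1 to compound 2 (within the scatter) and a number 5 percentage points higher from compound 1 to compound 3 (within the scatter), show that changes of similar scale left the number within the scatter. The expected step is therefore a number 3 percentage points lower from compound 3 to compound 4 (within the scatter), none beyond the scatter. Compound 4 is estimated at 95%, with a range from 84% to 106%.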

Compound 4, a percentage reported as activity, at one concentration (the size of the read-out at that concentration, not a potency): 57%
Estimate against measurement, compound 4: 38 percentage points above, and the stated range ends above it.
By their numbers in this assay, from the lowest: compound 4; then compounds 2, 1 and 3 (each within the scatter of the next, the first and the last beyond it).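

In this assay, the step of a number 41 percentage points lower from compound 3 to compound 4 (beyond the scatter) is the only one here that lies beyond the scatter, and it turns on a single atom: 4-chloro-3-(trifluoromethyl)phenyl becomes 3-(trifluoromethyl)phenyl, and the lower number stands for a stronger effect at the one concentration tested. Compounds 1, 2 and 3 all keep the chloro at this position, para to a large group, and the steps that change other places, a number 6 percentage points lower from compound 1 to compound 2 (within the scatter) and a number 5 percentage points higher from compound 1 to compound 3 (within the scatter), showed no such sensitivity, so the read-out in this small set moves only when this chloro is replaced by hydrogen. Nothing available here explains why this replacement has so large an effect.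

The compounds shown leave open whether the chloro itself holds the effect back or whether any group at this position would do so, a question that a fluoro, a methyl or an amine in its place could address. They also leave open whether the same replacement would carry over to the hydroxy compound 1 or to the dichloro compound 2, which differ from compound 3 elsewhere.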